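A few compounds are considered here, and "the series" means these few. Any claim that something is new, unique, unknown or untested is made for them only; others in the source may bear on it.

Working notes on the series. Compound 1 `O=[N+]([O-])c1cccc(NS(=O)(=O)c2ccccc2)c1`, compound 2 `COc1ccc(S(=O)(=O)Nc2cccc([N+](=O)[O-])c2)cc1` and compound 3 `COc1ccc(S(=O)(=O)Nc2ccc(C)cc2)cc1` have been measured in a physicochemical assay for acid dissociation; compound 4 `Cc1ccc(NS(=O)(=O)c2ccccc2)cc1` has not. In this assay compound 1 gives 7.93, compound 2 gives 8.44 and compound 3 gives 9.8, the highest of the three numbers, with compound 2 nearest to it and compound 1 furthest, both gaps beyond the scatter. The change from compound 2 to compound 1 is hydrogen in place of methoxy on an aromatic carbon, and it gave a number 0.51 log units lower from compound 2 to compound 1 (beyond the scatter). The difference between the cores of compound 3 and compound 2 is not broken down here. The change from compound 3 to compound 4 is hydrogen in place of methoxy on an aromatic carbon, the same change at the same place as before; among the compounds shown it occurs twice in all. Because a number 0.51 log units lower from compound 2 to compound 1 (beyond the scatter) was seen on the other core, a step of similar size is expected from compound 3 to compound 4, namely a number 0.50 log units lower from compound 3 to compound 4 (beyond the scatter), in this assay. Compound 4 is therefore estimated to give 9.3 in this assay, with the expected range running from 9 to 9.6.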

Compound 4, acid dissociation constant: 9.34
For compound 4 the middle estimate is 0.04 log units below the measured one; measured number inside the range.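

In this assay hydrogen in place of methoxy on an aromatic carbon, para to a large group, gave a number 0.46 log units lower from compound 3 to compound 4 (beyond the scatter) and, on the other core, a number 0.51 log units lower from compound 2 to compound 1 (beyond the scatter) with the two steps running in the same direction and close in size. This shows that the change carried from one core to the other in these two matched pairs, but two pairs cannot show that it holds on any further core of the series or at any other place on the ring. Nothing measured here accounts for the size of the step or for its similarity on the two cores.

On these data alone, whether an amine, a carboxylic acid or a longer chain such as ethoxy in that same place would give a step of comparable size or direction remains open. The compounds shown also leave open how the difference between the cores of compound 2 and compound 3 divides among its separate parts.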